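Shrinking the Sulfonyl Side Chain: Cyclobutyl to Methyl

The compounds below may be only part of what the source reports. "The series", "measured", "known", "first", "only" and "open" are said of these compounds alone.

Measured compounds:
compound 1 `O=C(NC[C@]1(CC2CC2)CC[C@H](S(=O)(=O)CC2CC2)CC1)c1ccc(Cl)cc1Cl` gives 29 nM in an assay on isolated protein for inhibition of sodium- and chloride-dependent glycine transporter 1 (Homo sapiens), with a stated time of 15 min; a higher number here means a weaker inhibitor, a lower number a stronger inhibitor
compound 2 `O=C(NC[C@]1(CC2CC2)CC[C@H](S(=O)(=O)CC2CCC2)CC1)c1ccc(Cl)cc1Cl` gives 629 nM in this assay

For the measured compounds named here, compound 2 stands at the highest number of the two, so it is the weaker inhibitor; its only neighbour is compound 1, and the step of a 22-fold higher number from compound 1 to compound 2 (1.34 log units; beyond the scatter) is large and well beyond the scatter. That step enlarged the ring on the saturated chain carbon bound to the sulfonyl sulfur from cyclopropyl to cyclobutyl.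

Compound 3 `CCS(=O)(=O)[C@H]1CC[C@](CNC(=O)c2ccc(Cl)cc2Cl)(CC2CC2)CC1` goes the other way: methyl in place of cyclobutyl on a saturated chain carbon bound to a sulfonyl sulfur. Going by the values given here, the single measured step bears on it. Because a 22-fold higher number from compound 1 to compound 2 (1.34 log units; beyond the scatter) shows that enlarging that group cost potency, removing the ring altogether is expected to recover much or all of it, giving a step in this assay toward a lower number, roughly the reverse of what was lost. Compound 3 is therefore estimated at 30 nM, with a range from 8 nM to 120 nM, which means an expected step of a 21-fold lower number from compound 2 to compound 3 (1.32 log units; beyond the scatter).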

Compound 3, half-maximal inhibitory concentration: 132 nM
For compound 3 the middle estimate is 4.4-fold (0.64 log units) below the measured one; measured number above the stated range.
By their numbers in this assay, from the lowest: compound 1; then compound 3; then compound 2.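

Replacing cyclobutyl with methyl wins back only part of the lost potency, with a 4.8-fold lower number from compound 2 to compound 3 (0.68 log units; beyond the scatter), while a 4.6-fold higher number from compound 1 to compound 3 (0.66 log units; beyond the scatter) shows that the methyl group still falls short of cyclopropyl. In this assay, the number therefore does not move in one direction with group size at this place: cyclopropyl, larger than methyl and smaller than cyclobutyl, gives the lowest number of the three, and both other groups give higher ones. Nothing available explains this order.

As far as these compounds go, it remains open whether the ring itself matters or only the size of the group, a question that a straight propyl chain on the same saturated chain carbon could help to answer. From the compounds shown here alone, how a group carrying an amine or a hydroxyl would fare at this place also remains unknown.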